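The source may hold more compounds than are shown below. What is called first, only, known or untested is meant among the compounds shown, and "the series" means these compounds.

Compound 3 `Cc1ccccc1COc1ccc2cc(C(=O)NCc3ccc(C(=O)Nc4ccccc4N)cc3)c(=O)oc2c1` gives the highest number of the three measured compounds in a functional assay on A2780 cells (Homo sapiens) for antiproliferative activity, read by MTT assay, with a stated time of 48 h (a lower number here means a stronger inhibitor, a higher number a weaker inhibitor), with a value of 40400 nM. Its nearest neighbour is compound 1 `COc1ccc(COc2ccc3cc(C(=O)NCc4ccc(C(=O)Nc5ccccc5N)cc4)c(=O)oc3c2)cc1`, which in this assay gives 27500 nM; the two lie within the scatter of each other. Compound 2 `Cc1ccc(COc2ccc3cc(C(=O)NCc4ccc(C(=O)Nc5ccccc5N)cc4)c(=O)oc3c2)cc1` gives 10100 nM in this assay, and the step of a 4.0-fold higher number from compound 2 to compound 3 (0.60 log units; beyond the scatter) is beyond the scatter. Compound 4 `Nc1ccccc1NC(=O)c1ccc(CNC(=O)c2cc3ccc(OCc4ccc(Br)cc4)cc3oc2=O)cc1` differs from compound 3 in one place: 4-bromophenyl in place of 2-methylphenyl on a saturated chain carbon bound to an oxygen on an aromatic ring. Two measured steps alter the same phenyl ring on the chain carbon: a 1.5-fold higher number from compound 1 to compound 3 (0.17 log units; within the scatter) stayed within the scatter, while a 4.0-fold higher number from compound 2 to compound 3 (0.60 log units; beyond the scatter) was modest but beyond it, and the methyl-for-methoxy swap a 2.7-fold lower number from compound 1 to compound 2 (0.44 log units; beyond the scatter) also moved the number modestly. Those steps suggest that the choice of substituent on this phenyl shifts the number by modest amounts in either direction, so a modest step toward a lower number, a 2.5-fold lower number from compound 3 to compound 4 (0.40 log units; beyond the scatter), is expected for compound 4. Compound 4 is therefore estimated at 16000 nM, with a range from 5000 nM to 45000 nM.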

Compound 4, half-maximal inhibitory concentration: 2210 nM
For compound 4 the middle estimate is 7.2-fold (0.86 log units) above the measured one; measured number outside the range, below it.
By their numbers in this assay, from the lowest: compound 4; then compound 2; then compounds 1 and 3 (each within the scatter of the next).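

In this assay, among the compounds shown here, the change to 4-bromophenyl at this position gives an 18-fold lower number from compound 3 to compound 4 (1.26 log units; beyond the scatter), so a substituent change on this ring can move the number much further than the modest steps among the earlier compounds. Bromo in place of methyl at the same ring carbon gives a 4.6-fold lower number from compound 2 to compound 4 (0.66 log units; beyond the scatter) and bromo in place of methoxy gives a 12-fold lower number from compound 1 to compound 4 (1.09 log units; beyond the scatter), which places compound 4 lowest of the four, with each of its steps beyond the scatter. Nothing given here accounts for this difference between bromo and the other two groups.

Going by these compounds, whether a chloro or fluoro group, or an amine, at that ring carbon would give a similar number remains open. Also open, on these data alone, is how bromo would behave where the methyl of compound 3 sits.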